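This account rests on a few compounds, and the source may have more. Where it says the series, first, only, none or still open, it means among the compounds named here.

Compounds in hand and their numbers in a functional assay on CHO cells for agonist activity at Free fatty acid receptor 1 (Homo sapiens), read by FLIPR and calcium flux; a lower number here means that less compound is needed, a higher number that more compound is needed for the effect:
- compound 1 `CCOc1ccc(C)c(-c2cccc(COc3ccc(OCC(=O)O)c(F)c3)c2)c1`: 220 nM
- compound 3 `Cc1ccc(OCC2CC2)cc1-c1cccc(COc2ccc(OCC(=O)O)c(F)c2)c1`: 340 nM
- compound 2 `Cc1ccc(OCC2CCCCC2)cc1-c1cccc(COc2ccc(OCC(=O)O)c(F)c2)c1`: 910 nM

Compound 2 gives the highest number of the three in this assay. Its nearest neighbour is compound 3, with a 2.7-fold lower number from compound 2 to compound 3 (0.43 log units; beyond the scatter) on the way from one to the other; its furthest is compound 1, reached by a 4.1-fold higher number from compound 1 to compound 2 (0.62 log units; beyond the scatter) in the reverse direction. Both separations are beyond the scatter, so compound 2 stands apart from the other two.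

The next compound, compound 4 `Cc1ccc(OCC2CCC2)cc1-c1cccc(COc2ccc(OCC(=O)O)c(F)c2)c1`, differs from compound 2 in one place: cyclobutyl in place of cyclohexyl on a saturated chain carbon bound to an oxygen on an aromatic ring. The measured steps that bear on this change are those at the same position. Going from methyl to cyclopropyl, a 1.5-fold higher number from compound 1 to compound 3 (0.19 log units; within the scatter), stays within the scatter; going from methyl to cyclohexyl, a 4.1-fold higher number from compound 1 to compound 2 (0.62 log units; beyond the scatter), and from cyclohexyl to cyclopropyl, a 2.7-fold lower number from compound 2 to compound 3 (0.43 log units; beyond the scatter), are both modest and beyond the scatter. The cyclobutyl group sits between cyclopropyl and cyclohexyl in what is counted, so a number between compound 3 and compound 2 is expected, a modest step toward lower values. The estimated step is a 1.8-fold lower number from compound 2 to compound 4 (0.26 log units; within the scatter), and compound 4 is expected to give about 500 nM, with a plausible range of 250 nM to 1000 nM.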

Compound 4, half-maximal effective concentration: 1530 nM
Estimate against measurement, compound 4: 3.1-fold (0.49 log units) below; the whole stated range lies below it.
By their numbers in this assay, from the lowest: compounds 1 and 3 (each within the scatter of the next); then compounds 2 and 4 (each within the scatter of the next).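

In this assay, cyclobutyl in place of cyclohexyl on the saturated chain carbon bound to an oxygen on an aromatic ring gives a 1.7-fold higher number from compound 2 to compound 4 (0.23 log units; within the scatter), so these two rings cannot be told apart here, while cyclobutyl in place of cyclopropyl gives a 4.5-fold higher number from compound 3 to compound 4 (0.65 log units; beyond the scatter) and cyclobutyl in place of methyl gives a 7.0-fold higher number from compound 1 to compound 4 (0.84 log units; beyond the scatter). The four compounds therefore fall into two sets, compounds 1 and 3 on one side and compounds 2 and 4 on the other, with the separation arising at the change from cyclopropyl to cyclobutyl rather than at the change from cyclobutyl to cyclohexyl, and compound 4 goes against any steady rise in the number with the heavy atoms counted in the ring. Nothing in hand speaks to what lies behind this separation.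

Open, from the compounds shown here alone, is where cyclopentyl would fall, and whether it would join compounds 2 and 4. Also open, going by these compounds, is whether a ring holding oxygen, such as oxetanyl, or an open chain such as propyl, would follow the same two sets at this position.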